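Enaminone pyrazoles: trimethoxyphenyl on the amine nitrogen

The source may report more compounds than this note shows. Statements on the series, on what has been measured and on what is new or still open speak of the compounds shown alone.

Measured so far:
compound 1 `COc1ccc(N/C=C\C(=O)c2cn(-c3ccccc3)nc2-c2ccc(OC)cc2)cc1`, 13400 nM;
compound 2 `COc1ccc(-c2nn(-c3ccccc3)cc2C(=O)/C=C\Nc2cc(OC)c(OC)c(OC)c2)cc1`, 18900 nM;
compound 3 `COc1ccc(N/C=C\C(=O)c2cn(-c3ccccc3)nc2-c2cc(OC)c(OC)c(OC)c2)cc1`, 9600 nM.

All values come from a functional assay on PC-3 cells (Homo sapiens) for antiproliferative activity, read by MTT assay, with a stated time of 48 h; a higher number here means a weaker inhibitor, a lower number a stronger inhibitor. Compound 2 differs from compound 1 by 3,4,5-trimethoxyphenyl in place of 4-methoxyphenyl on an amine nitrogen, and this gave a 1.4-fold higher number from compound 1 to compound 2 (0.15 log units; within the scatter). Compound 3 differs from compound 1 by 3,4,5-trimethoxyphenyl in place of 4-methoxyphenyl on an aromatic carbon, giving a 1.4-fold lower number from compound 1 to compound 3 (0.14 log units; within the scatter). Compound 4 `COc1cc(N/C=C\C(=O)c2cn(-c3ccccc3)nc2-c2cc(OC)c(OC)c(OC)c2)cc(OC)c1OC` is not yet measured; it differs from compound 3 by 3,4,5-trimethoxyphenyl in place of 4-methoxyphenyl on an amine nitrogen, the same change already seen between compound 1 and compound 2, here made on the core of compound 3.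

The expected step is a 1.4-fold higher number from compound 3 to compound 4 (0.13 log units; within the scatter), resting on a 1.4-fold higher number from compound 1 to compound 2 (0.15 log units; within the scatter) being within the scatter. In this assay compound 4 is estimated at 13000 nM, expected between 6000 nM and 30000 nM.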

Compound 4, half-maximal inhibitory concentration: 14100 nM
Beside the measured number, compound 4's estimate is 1.1-fold (0.04 log units) below it, and the stated range covers the measured number.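

In this assay, the change on the amine nitrogen, a 1.5-fold higher number from compound 3 to compound 4 (0.17 log units; within the scatter), matches its earlier counterpart: the same change on two cores in this assay, a 1.4-fold higher number (0.15 log units; within the scatter) from compound 1 to compound 2 and a 1.5-fold higher number (0.17 log units; within the scatter) from compound 3 to compound 4, 1.0-fold (0.02 log units) apart, within the scatter of two such steps. The change on an aromatic carbon, a 1.3-fold lower number from compound 2 to compound 4 (0.13 log units; within the scatter), likewise carries over between cores: the same change on two cores in this assay, a 1.4-fold lower number (0.14 log units; within the scatter) from compound 1 to compound 3 and a 1.3-fold lower number (0.13 log units; within the scatter) from compound 2 to compound 4, 1.0-fold (0.02 log units) apart, within the scatter of two such steps. For the compounds shown here, both changes therefore behave alike on the two cores tested, but every step lies within the scatter, so this shows only that neither change moved the number measurably on these cores, not that either has a real effect or would transfer to other cores.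

Still open, on these data alone, is whether a different group in these places, such as a simple alkyl chain or a carboxylic acid-bearing phenyl on the amine nitrogen, would give a step beyond the scatter.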